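The source may report more compounds than this note shows. Statements on the series, on what has been measured and on what is new or still open speak of the compounds shown alone.

Measured in a functional assay on MCF7 cells (Homo sapiens) for inhibition, read by sulforhodamine B assay, with a stated time of 72 h; on this read-out lower numbers stand for stronger inhibition of growth and higher numbers for weaker inhibition of growth:
- Compound 1 `CCOC(=O)/C=C/c1ccncc1-c1ccc2c(cnn2C)c1`: 7320 nM
- Compound 2 `Cn1ncc2cc(-c3cnccc3/C=C/C(=O)O)ccc21`: > 10000 nM, a limit and not a number

On these data alone, compound 2 has only this limit in this assay, so its exact place on the scale is unknown.

Compound 3 `CNC(=O)/C=C/c1ccncc1-c1ccc2c(cnn2C)c1` carries methylamino in place of hydroxy on a carbonyl carbon. Among the measured compounds shown here, the only measured step that bears on this change is an at least 1.3-fold higher number from compound 1 to compound 2 (0.13 log units; that floor lies within the scatter). With nothing larger measured, no change beyond the scatter is expected in this assay. The expected step is an at least 1.2-fold lower number from compound 2 to compound 3 (0.09 log units; that floor lies within the scatter). For compound 3 the estimated value is 8000 nM, with an expected range of 3000 nM to 20000 nM.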

Compound 3, concentration for 50% growth inhibition: > 10000 nM
Compound 3 gave a limit, no number (the forecaster's own chance of this, stated with the estimate: 45%); middle value at least 1.2-fold (0.09 log units) from the limit.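

In this assay compound 3 gives > 10000 nM, a limit and not a number. Methylamino in place of ethoxy on a carbonyl carbon gives an at least 1.3-fold higher number from compound 1 to compound 3 (0.13 log units; that floor lies within the scatter), so this change shows no gain in growth inhibition over the ethyl ester. The step between the hydroxy and methylamino groups cannot be read, and the read-out does not separate them at this position: the limit of > 10000 nM in this assay, at which 2 of the 3 values shown sit.

On these data alone, how far either compound lies past the limit stays open. Also open, as far as these compounds go, is whether a longer ester chain or a morpholine amide on this carbonyl carbon would give a measurable value.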